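Thiosemicarbazone series on a cyclohexenyl amine: aryl swap

A few compounds are considered here, and "the series" means these few. Any claim that something is new, unique, unknown or untested is made for them only; others in the source may bear on it.

Measured so far:
Compound 1 `CC1=CC[C@H](C(C)(C)N=C=S)CC1` — in a functional assay on OVCAR-3 cells (Homo sapiens) for inhibition, read by sulforhodamine B assay, with a stated time of 48 h (on this read-out higher numbers stand for weaker inhibition of growth and lower numbers for stronger inhibition of growth), compound 1 gives > 100000 nM, which is a limit of the assay.
Compound 2 `COc1ccc(/C=N/NC(=S)NC(C)(C)[C@H]2CC=C(C)CC2)cc1` — in this assay compound 2 gives 21200 nM.
Compound 3 `CC1=CC[C@H](C(C)(C)NC(=S)N/N=C/c2ccc(N(C)C)cc2)CC1` — in this assay compound 3 gives > 100000 nM, again a limit.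

Among the compounds with values here, compound 2 holds the only numerical value in this assay; the other two results sit at the limit of > 100000 nM in this assay, at which 2 of the 3 values shown sit, and so cannot be placed on the scale. Within the data shown here, the single step between numbered positions, an at least 4.7-fold higher number from compound 2 to compound 3 (0.67 log units; beyond the scatter), goes toward weaker inhibition, with the dimethylamino compound reaching the limit.

Compound 4 `CC1=CC[C@H](C(C)(C)NC(=S)N/N=C/c2ccccc2Cl)CC1` is the next aryl variant: 2-chlorophenyl in place of 4-methoxyphenyl on a carbon with a double bond to nitrogen. Among the measured compounds shown here, the only measured change on this aryl group is the one from compound 2 to compound 3, and it moved beyond the scatter toward the limit. No shown step in this assay tells how a 2-chlorophenyl group behaves, so the expectation leans on that one step and on the fact that two of three compounds reach the limit. A step toward a higher number, of modest size, is expected, with a real chance that only a limit is reported.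

The step expected is a 1.9-fold higher number from compound 2 to compound 4 (0.28 log units; within the scatter). For compound 4 the estimate is 40000 nM, between 12000 nM and 100000 nM.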

Compound 4, concentration for total growth inhibition: 83600 nM
Compound 4: middle estimate off by 2.1-fold (0.32 log units), on the low side, within the range that was stated.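

In this assay, within the data shown here, the change from 4-methoxyphenyl to 2-chlorophenyl on a carbon with a double bond to nitrogen gives a 3.9-fold higher number from compound 2 to compound 4 (0.60 log units; beyond the scatter), the first step at this place with a measured number at both ends. With the dimethylamino change in compound 3, both shown aryl changes away from compound 2 now go toward weaker inhibition, a pattern that rests on these two steps only and that no compound shown goes against. Compound 4 carries a number and not a limit, so leaving 4-methoxyphenyl does not in itself take a compound off the scale, though the readable part of the set stays small: the limit of > 100000 nM in this assay, at which 2 of the 4 values shown sit.

The compounds shown do not separate the loss of methoxy from the arrival of chlorine in this step, and an unsubstituted phenyl group would do that. Also open, going by these compounds, is whether any other aryl group on the shared core, such as a pyridyl or a 4-fluorophenyl group, gives a lower number than compound 2.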